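Longer Chain at the Lactam Amide: Estimating Compound 4

A few compounds are considered here, and "the series" means these few. Any claim that something is new, unique, unknown or untested is made for them only; others in the source may bear on it.

Measured so far:
- Compound 1, `O=C(CCCc1ccccc1)CC(=O)N[C@H]1CCOC1=O`: > 100000 nM
- Compound 2, `O=C(CCCCCCCCc1ccccc1)N[C@H]1CCOC1=O`: 67000 nM
- Compound 3, `O=C(CCc1ccccc1)CC(=O)N[C@H]1CCOC1=O`: > 100000 nM

All three compounds were tested in a functional assay on PC-3 cells (Homo sapiens) for cytotoxicity, read by sulforhodamine B assay, with a stated time of 5 days; a lower number here means a stronger inhibitor, a higher number a weaker inhibitor. Compound 1 gives > 100000 nM, which is a limit of the assay and not a number. Compound 3 likewise gives > 100000 nM, again a limit. Within the data shown here, only compound 2 gives a number, 67000 nM, and this stands as the single measured value among the three, since two of the three results sit at the limit of > 100000 nM in this assay, at which 2 of the 3 values shown sit.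

The change from compound 3 to compound 1 is benzyl in place of phenyl on a saturated chain carbon, two bonds along the chain from a carbonyl carbon. Its size is a step that the two limits leave unreadable from compound 3 to compound 1, so nothing can be read from it. How the core of compound 2 differs from that of compound 3 is not broken down here.

Compound 4, `O=C(CCCCCCCCCc1ccccc1)N[C@H]1CCOC1=O`, has not yet been measured. It differs from compound 2 by benzyl in place of phenyl on a saturated chain carbon, eight bonds along the chain from a carbonyl carbon. This is the same kind of change as from compound 3 to compound 1, but not the same: there the place is two bonds along the chain from a carbonyl carbon, here it is eight bonds along the chain from a carbonyl carbon. Among the measured compounds shown here, the only measured instance of this kind of change gave no readable size, so the expectation rests on compound 2 alone, at 67000 nM. The step from compound 2 to compound 4 is expected to be about a 1.3-fold lower number from compound 2 to compound 4 (0.13 log units; within the scatter). Compound 4 is therefore estimated at 50000 nM in this assay, expected between 20000 nM and 150000 nM.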

Compound 4, half-maximal inhibitory concentration: 75000 nM
Compound 4: middle estimate off by 1.5-fold (0.18 log units), on the low side, within the range that was stated.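

In this assay, putting benzyl in place of phenyl on the core of compound 2, eight bonds along the chain from a carbonyl carbon, gives a 1.1-fold higher number from compound 2 to compound 4 (0.05 log units; within the scatter), so at this place the change makes no difference that can be told from ordinary assay scatter. The same kind of change on the core of compound 3, two bonds along the chain from a carbonyl carbon, cannot be read, since compound 3 and compound 1 each give a limit of the assay and not a number: the limit of > 100000 nM in this assay, at which 2 of the 4 values shown sit. This leaves one readable instance of the change, and a single instance shows only what happens on the core of compound 2; it cannot show whether the result carries over to another core, or to another place on the chain.

The compounds shown leave open whether a still longer chain on the core of compound 2 would move the value beyond the scatter. They also leave open what an amine or a carboxylic acid in place of the phenyl ring at the chain end would do in this cell assay.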